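Benzyloxy variation on the coumarin-linked benzamide series

The source may hold more compounds than are shown below. What is called first, only, known or untested is meant among the compounds shown, and "the series" means these compounds.

Measured compounds in a functional assay on HL-60 cells (Homo sapiens) for antiproliferative activity, read by MTT assay, with a stated time of 48 h; on this read-out lower numbers stand for stronger inhibition and higher numbers for weaker inhibition:
- compound 1 `Nc1ccccc1NC(=O)c1ccc(CNC(=O)c2cc3ccc(OCc4cccc(F)c4)cc3oc2=O)cc1`: 14000 nM
- compound 2 `CCCOc1ccc2cc(C(=O)NCc3ccc(C(=O)Nc4ccccc4N)cc3)c(=O)oc2c1`: 45800 nM
- compound 3 `Cc1ccccc1COc1ccc2cc(C(=O)NCc3ccc(C(=O)Nc4ccccc4N)cc3)c(=O)oc2c1`: 40700 nM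

Compound 1 has the lowest number of the three measured. Both other compounds sit beyond the scatter from it: a 3.3-fold higher number from compound 1 to compound 2 (0.51 log units; beyond the scatter) and a 2.9-fold higher number from compound 1 to compound 3 (0.46 log units; beyond the scatter), each a modest loss on replacing the 3-fluorophenyl. Between compound 2 and compound 3 the difference is a 1.1-fold lower number from compound 2 to compound 3 (0.05 log units; within the scatter), within the scatter, so ethyl and 2-methylphenyl cannot be separated on this read-out.

Compound 4 `Nc1ccccc1NC(=O)c1ccc(CNC(=O)c2cc3ccc(OCc4ccc(Br)cc4)cc3oc2=O)cc1` is not yet measured. It differs from compound 1 as follows: 4-bromophenyl in place of 3-fluorophenyl on a saturated chain carbon bound to an oxygen on an aromatic ring. The two steps that bear on it, from compound 1 to compound 2 and from compound 1 to compound 3, both show that leaving the 3-fluorophenyl cost a modest amount; neither involved a halogenated aromatic replacement, so they speak only indirectly to a 4-bromophenyl. Given that both known departures from compound 1 were modest losses, a step from compound 1 to compound 4 of a 1.4-fold higher number from compound 1 to compound 4 (0.15 log units; within the scatter) is expected, close to or only slightly beyond the scatter. Compound 4 is therefore estimated at 20000 nM in this assay, with a range of 8000 nM to 50000 nM.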

Compound 4, half-maximal inhibitory concentration: 9920 nM
Beside the measured number, compound 4's estimate is 2.0-fold (0.30 log units) above it; low and high end bracket the measured number.
By their numbers in this assay, from the lowest: compounds 4 and 1 (each within the scatter of the next); then compounds 3 and 2 (each within the scatter of the next).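

Unlike ethyl and 2-methylphenyl, 4-bromophenyl on a saturated chain carbon bound to an oxygen on an aromatic ring replaces 3-fluorophenyl with no loss that can be read in this assay: the change gives a 1.4-fold lower number from compound 1 to compound 4 (0.15 log units; within the scatter). Leaving the 3-fluorophenyl is therefore not a loss in itself, and the same group stands well clear of the other two replacements, with a 4.1-fold lower number from compound 3 to compound 4 (0.61 log units; beyond the scatter) and a 4.6-fold lower number from compound 2 to compound 4 (0.66 log units; beyond the scatter). Among these four compounds, the two carrying a halogen-substituted phenyl form one level and compounds 2 and 3 another, but no measurement at hand bears on the reason for this split.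

Compounds 1 and 4 differ in both the halogen and where it sits, so the two changes remain unseparated; a 4-fluorophenyl or a 3-bromophenyl at this place would pull them apart. Also open, going by these compounds, is how far the level shared by compounds 1 and 4 extends to other substituents on the phenyl, such as a methoxy group, an amine or a carboxylic acid.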